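Working notes on a small sulfide series and one untested analogue

The source may report more compounds than this note shows. Statements on the series, on what has been measured and on what is new or still open speak of the compounds shown alone.

Measured so far:
- compound 1, `CSc1ccc(/C=C(/SCc2ccc(Cl)cc2)C(=O)c2ccc(Cl)cc2)cc1`: 25000 nM
- compound 3, `CSc1ccc(/C=C(/SCc2ccc(C)cc2)C(=O)c2ccc(Cl)cc2)cc1`: 25000 nM
- compound 2, `CSc1ccc(/C=C(/SCc2ccc(Cl)cc2)C(=O)c2ccc(C(=O)O)cc2)cc1`: this value is a limit of the assay, > 100000 nM

In a functional assay on DU-145 cells (Homo sapiens) for inhibition, read by trypan blue exclusion, with a stated time of 96 h (a higher number here means a weaker inhibitor of growth, a lower number a stronger inhibitor of growth), compound 1 gives 25000 nM and stands level with compound 3, which gives 25000 nM; the step of no change at the digits printed from compound 1 to compound 3 (within the scatter). Compound 2 reaches only a limit in this assay, > 100000 nM (the limit of > 100000 nM in this assay, at which 1 of the 3 values shown sits). The step of an at least 4.0-fold higher number from compound 1 to compound 2 (0.60 log units; beyond the scatter) is therefore the only one in the set that moves beyond the scatter, and it sits on the benzoyl ring.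

Compound 4, `O=C(/C(=C\c1ccc(O)cc1)SCc1ccc(Cl)cc1)c1ccc(Cl)cc1`, differs from compound 1 on the third ring: hydroxy in place of methylsulfanyl on an aromatic carbon. Neither measured step touches that ring, so the two known steps bear only indirectly. The step from compound 1 to compound 3 shows that swapping one small substituent for another can leave this assay unchanged; the step from compound 1 to compound 2 shows that a change of substituent type can push a value to the limit. A step somewhere between these, weakening at most modestly, is expected: a 1.6-fold higher number from compound 1 to compound 4 (0.20 log units; within the scatter). Compound 4 is accordingly estimated at 40000 nM in this assay, with a range from 15000 nM to 100000 nM, and a real chance that only a limit is reported.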

Compound 4, concentration for 50% growth inhibition: 10000 nM
Compound 4: middle estimate off by 4.0-fold (0.60 log units), on the high side, and the stated range ends above it.
By their numbers in this assay, from the lowest: compound 4; then compounds 1 and 3 (each within the scatter of the next). At a limit, above all of these: compound 2.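

Within the data shown here, until now this position had been held fixed, so the change to 4-hydroxyphenyl gives its first reading in this assay: hydroxy in place of methylsulfanyl yields a 2.5-fold lower number from compound 1 to compound 4 (0.40 log units; beyond the scatter) and is the first step in the set to reach a lower number beyond the scatter. The third ring therefore responds to substitution, and here a change on it moves the value in the opposite direction to the carboxy change on the benzoyl ring. The entering hydroxy has 1 heavy atom and 1 hydrogen-bond donor, whereas the leaving methylsulfanyl has 2 heavy atoms and no donor, but a single pair cannot separate these differences, and no measurement shown accounts for the step.

Whether the lower number is specific to hydroxy remains open, as the compounds shown do not include a methoxy group, an amine or a carboxylic acid on this aromatic carbon. Going by these compounds, it is also open whether the same exchange would give a similar step with the methyl-bearing benzyl group of compound 3 or with other changes on the benzoyl ring.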